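Swapping the Hydrazone Aryl Group for a Furan Ring

A few compounds are considered here, and "the series" means these few. Any claim that something is new, unique, unknown or untested is made for them only; others in the source may bear on it.

Measured so far in a functional assay on PC-3 cells (Homo sapiens) for inhibition; a lower number here means a stronger inhibitor, a higher number a weaker inhibitor:
- compound 1, `Cc1c(C(=O)N/N=C\c2ccc(O)cc2)oc2cccc(O)c12`: 21700 nM
- compound 2, `Cc1c(C(=O)N/N=C\c2cccnc2)oc2cccc(O)c12`: a limit of the assay, >= 40000 nM
- compound 3, `COc1ccccc1/C=N\NC(=O)c1oc2cccc(O)c2c1C`: 32700 nM

Compound 3 gives the highest of the two numbers, and its nearest neighbour, compound 1, sits within the scatter: a 1.5-fold higher number from compound 1 to compound 3 (0.18 log units; within the scatter). Compound 2 sits at a limit, (the limit of >= 40000 nM in this assay, at which 1 of the 3 values shown sits), so an at least 1.2-fold lower number from compound 2 to compound 3 (0.08 log units; that floor lies within the scatter) is only a floor that also lies within the scatter. Compound 4, `Cc1c(C(=O)N/N=C\c2ccco2)oc2cccc(O)c12`, differs from compound 3 by furan-2-yl in place of 2-methoxyphenyl on a carbon with a double bond to nitrogen. Within the data shown here, no measured step covers this change, and the steps that do touch the same carbon were all within the scatter, so no step beyond the scatter is expected in this assay. Compound 4 is therefore estimated at 35000 nM, between 15000 nM and 80000 nM. That estimate means an expected 1.1-fold higher number from compound 3 to compound 4 (0.03 log units; within the scatter).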

Compound 4, half-maximal inhibitory concentration: >= 40000 nM
Compound 4: a limit, no number; the forecaster's own chance of this, stated with the estimate: 35%; at least 1.1-fold (0.05 log units) between middle value and limit.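

In this assay, compound 4 gives a limit of the assay, not a number, so a five-membered aromatic ring on this carbon adds a second compound at that limit: the limit of >= 40000 nM in this assay, at which 2 of the 4 values shown sit.

The readable steps are only floors, an at least 1.2-fold higher number from compound 3 to compound 4 (0.08 log units; that floor lies within the scatter) and an at least 1.8-fold higher number from compound 1 to compound 4 (0.26 log units; that floor lies within the scatter), and the step between the two limits cannot be read. So far, no change on this carbon has given a step beyond the scatter.

Going by these compounds, how far compound 4 lies past its limit stays open. So does whether a quite different group here, such as a carboxylic acid, an amine or a longer chain, would change the result.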